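This account rests on a few compounds, and the source may have more. Where it says the series, first, only, none or still open, it means among the compounds named here.

In a functional assay on SK-OV-3 cells (Homo sapiens) for antiproliferative activity (a lower number here means a stronger inhibitor of growth, a higher number a weaker inhibitor of growth), compound 1 `c1ccc(-c2cc(-c3cccnc3)nc(-c3ccccn3)c2)cc1` gives 49.6 ug/mL while compound 2 `c1ccc(-c2cc(-c3ccsc3)cc(-c3ccccn3)n2)nc1` gives 0.1 ug/mL and compound 3 `c1ccc(-c2cc(-c3ccccn3)nc(-c3ccccn3)c2)cc1` gives (0.12 ug/mL). Compound 3 therefore stands level with compound 2 within the scatter and far under compound 1. Compound 4 `c1ccc(-c2cc(-c3ccco3)cc(-c3ccccn3)n2)nc1` differs from compound 3 in one place, with furan-2-yl in place of phenyl on an aromatic carbon, opposite the ring nitrogen (furan-2-yl in place of phenyl on an aromatic carbon). Going by the values given here, two measured steps bear on this change. The closer one swaps thiophen-3-yl for phenyl at the same place, and it gives only (a 1.2-fold higher number from compound 2 to compound 3 (0.08 log units; within the scatter)). The other, with pyridin-2-yl in place of pyridin-3-yl, is very large (a 410-fold lower number from compound 1 to compound 3 (2.62 log units; beyond the scatter)), but compound 4 keeps both pyridin-2-yl groups, so that step does not transfer to this change. Among the compounds with values here, no furan-2-yl compound has been measured yet, so the expectation rests on compound 2 at 0.1 ug/mL as the nearest analogue. The expected result is a step within the scatter (a 1.3-fold higher number from compound 3 to compound 4 (0.10 log units; within the scatter)). Compound 4 is estimated at 0.15 ug/mL (expected range 0.05 ug/mL to 0.5 ug/mL).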

Compound 4, concentration for 50% growth inhibition: 0.13 ug/mL
For compound 4 the middle estimate is 1.2-fold (0.06 log units) above the measured one; low and high end bracket the measured number.
By their numbers in this assay, from the lowest: compounds 2, 3 and 4 (each within the scatter of the next); then compound 1.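

In this assay, replacing phenyl with furan-2-yl on this aromatic carbon, opposite the ring nitrogen, leaves the number within the scatter (a 1.1-fold higher number from compound 3 to compound 4 (0.03 log units; within the scatter)), and the same holds for replacing thiophen-3-yl with furan-2-yl (a 1.3-fold higher number from compound 2 to compound 4 (0.11 log units; within the scatter)). Phenyl, thiophen-3-yl and furan-2-yl therefore stand level at this position, which now shows that the six-membered ring of carbon only and two different five-membered aromatic rings with one hetero atom all give numbers within the scatter of one another. Nothing available explains why these three groups stand level. The compounds shown leave open whether this position also tolerates a group that is not an aromatic ring, such as an amine, a carboxylic acid or a longer alkyl chain. They also leave open whether a methyl or chloro substituent on the furan-2-yl ring would change the number.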